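This account rests on a few compounds, and the source may have more. Where it says the series, first, only, none or still open, it means among the compounds named here.

Compound 1, `Cc1cc2[nH]nc(N)c2c(=O)[nH]1`, gives -1% in an assay on isolated protein for inhibition of serine/threonine-protein kinase D2 (Homo sapiens), read by mobility shift assay, tested at 30 uM; a higher number here means more inhibition at the concentration tested (going by the name of the read-out), a lower number less inhibition. Compound 2, `CC(C)(C)c1cc2[nH]nc(N)c2c(=O)[nH]1`, gives -15% in this assay. Compound 3, `Cc1cc2nn(-c3ccccc3)c(N)c2c(=O)[nH]1`, gives -1% in this assay.

Compound 1 and compound 2 share one core and differ by tert-butyl in place of methyl on an aromatic carbon; the step in this assay was a number 14 percentage points lower from compound 1 to compound 2 (beyond the scatter). Compound 3 carries a different core, and the difference between the two cores is not broken down here. In this assay compound 3 stands level with compound 1 at the digits shown, and the two together hold the highest numbers of the three measured, with compound 2 the furthest away.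

Compound 4, `CC(C)(C)c1cc2nn(-c3ccccc3)c(N)c2c(=O)[nH]1`, has not yet been measured in this assay. It differs from compound 3 by tert-butyl in place of methyl on an aromatic carbon, which is the same change that was made from compound 1 to compound 2. Because the measured step of a number 14 percentage points lower from compound 1 to compound 2 (beyond the scatter) was modest and the starting point of compound 3 matches that of compound 1, the expected step is a number 13 percentage points lower from compound 3 to compound 4 (beyond the scatter). Compound 4 is therefore estimated at -14% in this assay, with the expected range running from -30% to 4%.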

Compound 4, a percentage reported as inhibition, at one concentration (the size of the read-out at that concentration, not a potency): 15%
Estimate against measurement, compound 4: 29 percentage points below; the measured number lies above the stated range.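

On the core of compound 3, tert-butyl in place of methyl on an aromatic carbon gave a number 16 percentage points higher from compound 3 to compound 4 (beyond the scatter) in this assay. Set beside the step on the core of compound 1, the same change did not carry over from one core to the other, either in size or in direction: the same change on two cores in this assay, a number 14 percentage points lower (beyond the scatter) from compound 1 to compound 2 and a number 16 percentage points higher (beyond the scatter) from compound 3 to compound 4, 30 percentage points apart, beyond the scatter of two such steps. This shows that, for these two pairs, the step seen on one core did not predict the step on the other, but it does not show which feature of the cores separates the two steps, and two pairs read at a single concentration establish no general rule for the series.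

The compounds shown leave open whether other groups on that aromatic carbon, such as an amine, a carboxylic acid or a longer chain, would also behave differently on the two cores. They also leave open which part of the difference between the cores goes with the opposite steps.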